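Removing the amide methyl in a rotarod series

The compounds below may be only part of what the source reports. "The series", "measured", "known", "first", "only" and "open" are said of these compounds alone.

Compound 1 `CN(C(=O)CNC(=O)CN)c1ccc([N+](=O)[O-])cc1C(=O)c1ccccc1Cl` and compound 2 `NCC(=O)NCC(=O)Nc1ccc([N+](=O)[O-])cc1C(=O)c1ccccc1Cl` share one core; in a functional assay on the whole organism with Mus musculus as the target, in the rotarod test (a higher number here means that more compound is needed for the effect, a lower number that less compound is needed), compound 1 gives 10 mg/kg and compound 2 gives 63.9 mg/kg. The change between them, (hydrogen in place of methyl on an amide-type nitrogen), made the step of a 6.4-fold higher number from compound 1 to compound 2 (0.81 log units; beyond the scatter). Compound 3 `CC(=O)NCC(=O)N(C)c1ccc(Cl)cc1C(=O)c1ccccc1Cl` carries a different core; how its core differs from that of compound 1 is not broken down here. In this assay compound 3 gives 58 mg/kg, close to compound 2 and well apart from compound 1. Compound 4 `CC(=O)NCC(=O)Nc1ccc(Cl)cc1C(=O)c1ccccc1Cl` is not yet measured and differs from compound 3 by hydrogen in place of methyl on an amide-type nitrogen, the same change as that from compound 1 to compound 2, at the same place. For the measured compounds named here, the only measured example of this change is the rise seen in a 6.4-fold higher number from compound 1 to compound 2 (0.81 log units; beyond the scatter); on that alone a step in the same direction is expected for compound 4, a 4.3-fold higher number from compound 3 to compound 4 (0.63 log units; beyond the scatter), though the cores differ and the change occurs only twice here, so the size is uncertain. For compound 4 in this assay the expected value is 250 mg/kg, within 90 mg/kg to 700 mg/kg.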

Compound 4, dose for half-maximal effect: > 100 mg/kg
Compound 4 ended at the assay's limit; the forecaster's own chance of this, stated with the estimate: 20%; the middle value lies beyond the limit too.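

In this assay, hydrogen in place of methyl on the amide-type nitrogen gives an at least 1.7-fold higher number from compound 3 to compound 4 (0.23 log units; that floor lies within the scatter), which can be read only as a floor. Compound 4 gives > 100 mg/kg, which is a limit of the assay and not a number. The change therefore does not lower the number on the second core, and the step there is compatible with the earlier one, but the data neither show that its size carries over from one core to the other nor establish a step beyond the scatter on the second core: the same change on two cores in this assay, a 6.4-fold higher number (0.81 log units; beyond the scatter) from compound 1 to compound 2 and an at least 1.7-fold higher number (0.23 log units; that floor lies within the scatter) from compound 3 to compound 4; the limit leaves it open whether they differ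

The compounds shown leave open where compound 4 truly lies beyond its limit, so a size for this change on its core cannot yet be given. Also open, going by these compounds, is whether the step persists with a longer chain such as ethyl in place of methyl on that nitrogen, or on a core carrying another group such as a carboxylic acid.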